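The source may report more compounds than this note shows. Statements on the series, on what has been measured and on what is new or still open speak of the compounds shown alone.

Measured compounds:
Compound 1, `O=C(NC(=S)NNc1ncnc2ccccc12)c1ccccc1F`: 4610 nM
Compound 2, `COc1cc2ncnc(NNC(=S)NC(=O)c3ccc(C(F)(F)F)cc3)c2cc1OC`: 16500 nM

Both were tested in a functional assay on CNE-2 cells (Homo sapiens) for cytotoxicity, read by MTT assay, with a stated time of 72 h; a lower number here means a stronger inhibitor, a higher number a weaker inhibitor. Compound 1 gives the lowest of the two numbers; compound 2, which carries a different core and a different group on the carbonyl carbon, gives a number beyond the scatter of compound 1.

The next compound, compound 3, `Cc1ccc(C(=O)NC(=S)NNc2ncnc3ccccc23)cc1`, keeps the core of compound 1 and changes only one place: 4-methylphenyl in place of 2-fluorophenyl on a carbonyl carbon. Within the data shown here, no measured pair shows this change, so there is no step to lean on. The expected step from compound 1 to compound 3, a 1.2-fold higher number from compound 1 to compound 3 (0.08 log units; within the scatter), is small, with no clear direction beyond the scatter. Compound 3 is estimated at 5500 nM, with a range from 2000 nM to 16000 nM.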

Compound 3, half-maximal inhibitory concentration: 17200 nM
Beside the measured number, compound 3's estimate is 3.1-fold (0.50 log units) below it, and the stated range ends below it.
By their numbers in this assay, from the lowest: compound 1; then compounds 2 and 3 (each within the scatter of the next).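

On the shared core, the group on the carbonyl carbon is not a neutral place in this assay: 4-methylphenyl in place of 2-fluorophenyl gives a 3.7-fold higher number from compound 1 to compound 3 (0.57 log units; beyond the scatter) on a single change. The earlier pair differed in more than one place and could not isolate this position. Nothing measured here explains the step. From the compounds shown here alone, whether the loss of the fluorine or the arrival of the methyl carries the step stays open. So does how an unsubstituted phenyl, or a phenyl carrying an amine or a carboxylic acid, would read on this carbonyl carbon.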